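Replacing an Acetyl Sulfonamide with a Dimethoxypyrimidinyl Group

The compounds below may be only part of what the source reports. "The series", "measured", "known", "first", "only" and "open" are said of these compounds alone.

Of the compounds shown here, two have been measured in a functional assay on AS49-RAW cells (Homo sapiens) for antiproliferative activity, read by sulforhodamine B assay, with a stated time of 48 h; a higher number here means a weaker inhibitor, a lower number a stronger inhibitor. Going by the values given here, compound 1 `CC(=O)NS(=O)(=O)c1ccc(N/C(S)=N\c2ccnc3cc(C(F)(F)F)ccc23)cc1` gives 37600 nM there, which is the higher of the two numbers recorded, although the gap to its only neighbour lies within the scatter. Compound 2 `O=S(=O)(Nc1nccs1)c1ccc(N/C(S)=N\c2ccnc3cc(C(F)(F)F)ccc23)cc1` gives 27200 nM in this assay; the step between them is a 1.4-fold lower number from compound 1 to compound 2 (0.14 log units; within the scatter), so the two values cannot be told apart.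

Compound 3 `COc1ncnc(NS(=O)(=O)c2ccc(N/C(S)=N\c3ccnc4cc(C(F)(F)F)ccc34)cc2)c1OC` has not yet been measured. Compared with compound 1 the change is: 5,6-dimethoxypyrimidin-4-yl in place of acetyl on a sulfonamide nitrogen The one measured step that bears on this change is the one from compound 1 to compound 2, which likewise replaces the acetyl on the sulfonamide nitrogen with an aromatic heterocycle and stayed within the scatter. On that basis the step of a 1.4-fold lower number from compound 1 to compound 3 (0.16 log units; within the scatter) in this assay is expected to be small, with no change beyond the scatter, and at most a slight lowering of the number. Compound 3 is therefore estimated at 26000 nM in this assay, with a range from 10000 nM to 65000 nM.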

Compound 3, half-maximal inhibitory concentration: 81800 nM
Beside the measured number, compound 3's estimate is 3.1-fold (0.50 log units) below it, and the stated range ends below it.
By their numbers in this assay, from the lowest: compounds 2 and 1 (each within the scatter of the next); then compound 3.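

In this assay the sulfonamide nitrogen turns out not to be indifferent to what it carries: there is a 2.2-fold higher number from compound 1 to compound 3 (0.34 log units; beyond the scatter) and also a 3.0-fold higher number from compound 2 to compound 3 (0.48 log units; beyond the scatter), both modest, whereas the exchange of acetyl for 1,3-thiazol-2-yl stayed within the scatter. An aromatic heterocycle at this place therefore does not by itself leave the number unchanged, and compound 3 is the weakest of the three, since its steps to both others lie beyond the scatter. The entering 5,6-dimethoxypyrimidin-4-yl group brings 10 heavy atoms against 3 for acetyl and 4 hydrogen-bond acceptors against 1, but no evidence is available that would tie the rise to either count or to any other cause.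

The compounds shown cannot separate the contribution of the pyrimidine ring from that of its two methoxy groups, a question that a plain pyrimidin-4-yl group on the same nitrogen would address. They also leave open whether a small methyl group or a longer alkyl chain at this place would stay level with compound 1 or move the number in either direction.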